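Swapping a Ketone for an Ester on a Shared Core

The source may report more compounds than this note shows. Statements on the series, on what has been measured and on what is new or still open speak of the compounds shown alone.

Measured compounds:
Compound 1, `CC1=C(C(=O)C2CC2)C(c2ccco2)NC(=O)N1`: 7%
Compound 2, `CC1=C(C(=O)C2CC2)C(c2ccoc2)NC(=O)N1`: 16%
Compound 3, `CC1=C(C(=O)C2CC2)C(c2cccs2)NC(=O)N1`: 15%

In an assay on membranes from HeLa cells for displacement of a labelled ligand from adenosine receptor A3 (Homo sapiens), read by scintillation counting, with a stated time of 180 min, tested at 1 uM (a higher number here means more inhibition at the concentration tested (going by the name of the read-out), a lower number less inhibition), compound 1 gives 7%, the low end of the three numbers, though the gaps are small: a number 9 percentage points higher from compound 1 to compound 2 (within the scatter) and a number 8 percentage points higher from compound 1 to compound 3 (within the scatter), and between the other two, a number 1 percentage points lower from compound 2 to compound 3 (within the scatter). All three numbers sit together within the scatter, so none of the three can be said to be higher or lower than another.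

Compound 4, `CCC(CC)OC(=O)C1=C(C)NC(=O)NC1c1ccco1`, is a new case. It differs from compound 1 in one place: (pentan-3-yl)oxy in place of cyclopropyl on a carbonyl carbon. For the measured compounds named here, every measured step so far exchanged only the aromatic ring on the saturated ring carbon and left the carbonyl side untouched, so none of them bears on this change, and each was within the scatter anyway. There is therefore no measured guide for the size or direction of the step, only the starting point of compound 1 at 7%.

With nothing pointing elsewhere, compound 4 is expected to land near its parent, estimated at 10% with a range from 0% to 30%. The step of a number 3 percentage points higher from compound 1 to compound 4 (within the scatter) is expected to stay within the scatter.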

Compound 4, a percentage reported as inhibition, at one concentration (the size of the read-out at that concentration, not a potency): 1%
The estimate for compound 4 lay 9 percentage points above the measured number, within the range that was stated.
By their numbers in this assay, from the lowest: compounds 4, 1, 3 and 2 (each within the scatter of the next, the first and the last beyond it).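

For the compounds shown here, this is the first change on the carbonyl side of the shared core: in this assay, putting (pentan-3-yl)oxy in place of cyclopropyl on a carbonyl carbon gives a number 6 percentage points lower from compound 1 to compound 4 (within the scatter). Turning the ketone into an ester, with an open chain replacing a three-membered ring, therefore does not move the number beyond the usual scatter in this test at a single concentration. Nothing measured here offers an explanation for this result.

Still open, from the compounds shown here alone, is whether a methoxy or ethoxy group, or an amine, on the same carbonyl carbon would give a number beyond the scatter of compound 1. Also open, going by these compounds, is whether the (pentan-3-yl)oxy ester would act the same way with furan-3-yl or thiophen-2-yl on the saturated ring carbon.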